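The source may hold more compounds than are shown below. What is called first, only, known or untested is meant among the compounds shown, and "the series" means these compounds.

Compound 1 `COc1ccc(-c2cc(/C=C/C(=O)c3ccc(N)cc3)[nH]n2)cc1` gives 34100 nM in a functional assay on MCF7 cells (Homo sapiens) for inhibition, read by sulforhodamine B assay, with a stated time of 48 h; on this read-out higher numbers stand for lower toxicity in this test and lower numbers for higher toxicity in this test. Compound 3 `COc1ccc(-c2cc(/C=C/C(=O)c3ccc(N)cc3)[nH]n2)cc1OC` gives 71200 nM in this assay; the change methoxy in place of hydrogen on an aromatic carbon made a 2.1-fold higher number from compound 1 to compound 3 (0.32 log units; beyond the scatter). Compound 2 `COc1ccc(C(=O)/C=C/c2cc(-c3cc(OC)c(OC)c(OC)c3)n[nH]2)cc1OC` gives 5720 nM in this assay, the lowest of the three numbers; how its core differs from the core of compound 1 is not broken down here. Compound 4 `COc1cc(C(=O)/C=C/c2cc(-c3cc(OC)c(OC)c(OC)c3)n[nH]2)cc(OC)c1OC` is not yet measured. It differs from compound 2 by methoxy in place of hydrogen on an aromatic carbon, the same kind of change as from compound 1 to compound 3, though here the place is in addition meta to a methoxy group (2 heavy atoms). On the strength of a 2.1-fold higher number from compound 1 to compound 3 (0.32 log units; beyond the scatter), the step is expected to be a 1.6-fold higher number from compound 2 to compound 4 (0.20 log units; within the scatter), of like direction; with a single precedent the range is kept wide. Compound 4 is thus estimated at 9000 nM in this assay, from 3500 nM to 22000 nM.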

Compound 4, concentration lethal to 50% of the cells: 5220 nM
Compound 4: middle estimate off by 1.7-fold (0.24 log units), on the high side; measured number inside the range.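

In this assay, methoxy in place of hydrogen on an aromatic carbon made a 1.1-fold lower number from compound 2 to compound 4 (0.04 log units; within the scatter), so on this core the change leaves the number within the scatter. The step does not differ measurably from the earlier one on the core of compound 1: the same change on two cores in this assay, a 2.1-fold higher number (0.32 log units; beyond the scatter) from compound 1 to compound 3 and a 1.1-fold lower number (0.04 log units; within the scatter) from compound 2 to compound 4, 2.3-fold (0.36 log units) apart, within the scatter of two such steps. For the compounds shown here, this is compatible with the change carrying over between the two cores but does not establish it: there are only two steps, they sit on different cores, and the step within the scatter fixes no direction.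

Open, as far as these compounds go, is whether hydroxy, chlorine or a longer chain such as ethoxy in place of that hydrogen would move the number. Also open, from the compounds shown here alone, is how the methoxy change behaves on a third core.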